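Removing One Fluorine From Compound 2

The source may hold more compounds than are shown below. What is called first, only, known or untested is meant among the compounds shown, and "the series" means these compounds.

Compound 2 `Fc1ccc(-c2csc(Cn3ccnc3)c2)cc1F` was tested in an assay for inhibition of steroid 17-alpha-hydroxylase/17,20 lyase (Homo sapiens), using NADPH, tested at 2 uM (a higher number here means a stronger effect of the compound at the concentration tested, a lower number a weaker effect), and gave 25%. Among the two compounds measured so far it stands highest; the nearest is compound 1 `COc1ccc(-c2csc(Cn3ccnc3)c2)cc1`, which in this assay gave 13%, a gap that lies beyond the usual scatter. Since compound 1 and compound 2 differ in more than one place, their two values show only this difference and no single effect.

Compound 3 `Fc1ccc(-c2csc(Cn3ccnc3)c2)cc1` has not yet been measured. It differs from compound 2 by hydrogen in place of fluoro on an aromatic carbon. For the measured compounds named here, no step between measured compounds shows what such a change does here, so the expectation rests on compound 2 alone. Compound 3 is expected to stay near compound 2, with a step of a number 5 percentage points lower from compound 2 to compound 3 (within the scatter) that is estimated to fall within the scatter or slightly downward. The estimate for compound 3 is 20%, expected between 8% and 32%.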

Compound 3, a percentage reported as inhibition, at one concentration (the size of the read-out at that concentration, not a potency): 20%
Compound 3: middle estimate and measured number agree at the digits printed; the range from low to high includes it.
By their numbers in this assay, from the lowest: compounds 1, 3 and 2 (each within the scatter of the next, the first and the last beyond it).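

In this assay, the change at this position, hydrogen in place of fluoro on an aromatic carbon ortho to a fluoro group, gives a number 5 percentage points lower from compound 2 to compound 3 (within the scatter), so this fluoro group is not shown to matter for the read-out. The other change, fluoro in place of methoxy, gives a number 7 percentage points higher from compound 1 to compound 3 (within the scatter); compound 3 thus links compound 1 and compound 2 through two single changes, neither of which lies beyond the scatter on its own, although the values of compound 1 and compound 2 lie beyond it. Nothing at hand bears on why the read-outs fall as they do.

On these data alone, it remains open whether a chlorine atom, an amine or a carboxylic acid on this aromatic carbon would move the read-out beyond the scatter. Also open, as far as these compounds go, is whether these compounds would give a stronger or weaker effect at another concentration than at the one tested.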